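The source may report more compounds than this note shows. Statements on the series, on what has been measured and on what is new or still open speak of the compounds shown alone.

Compound 2 `C#CC(=O)N(Cc1ccc(OC)c(O)c1)c1cc(OC)c(OC)c(OC)c1` stands lowest of the three compounds measured in a functional assay on MGC-803 cells (Homo sapiens) for inhibition, read by MTT assay, with a stated time of 48 h (a lower number here means a stronger inhibitor, a higher number a weaker inhibitor), where compound 2 gives 170 nM. Compound 1 `C/C=C/C(=O)N(Cc1cccc(O)c1)c1cc(OC)c(OC)c(OC)c1` gives 14100 nM in this assay, and compound 3 `COc1ccc(CNc2cc(OC)c(OC)c(OC)c2)cc1Cl` gives 46200 nM, both far beyond the scatter from compound 2. Compound 4 `COc1ccc(CN(C(=O)C(C)C)c2cc(OC)c(OC)c(OC)c2)cc1O` has not yet been measured. It differs from compound 2 in one place: isopropyl in place of ethynyl on a carbonyl carbon. Since compound 1, which also carries an acyl group other than ethynylcarbonyl on the same amide-type nitrogen, gives 14100 nM, a move toward higher numbers is expected, and the step from compound 2 to compound 4 is estimated to be an 88-fold higher number from compound 2 to compound 4 (1.95 log units; beyond the scatter). In this assay compound 4 is therefore expected to give about 15000 nM, with a likely range from 3000 nM to 60000 nM.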

Compound 4, half-maximal inhibitory concentration: 210 nM
For compound 4 the middle estimate is 71-fold (1.85 log units) above the measured one; the whole stated range lies above it.
By their numbers in this assay, from the lowest: compounds 2 and 4 (each within the scatter of the next); then compound 1; then compound 3.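

In this assay, isopropyl in place of ethynyl on a carbonyl carbon reads as a 1.2-fold higher number from compound 2 to compound 4 (0.09 log units; within the scatter). For this pair, then, the ethynyl group and its triple bond are not needed for a number of this size, and the position takes isopropyl equally well. Nothing shown here accounts for this result. Going by these compounds, it remains open whether a longer chain, such as n-butyl, or a carbonyl carbon bearing an amine or a phenyl ring would stay in this range.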